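The compounds below may be only part of what the source reports. "The series", "measured", "known", "first", "only" and "open" are said of these compounds alone.

Measured compounds:
compound 1, `CC(C)CC(=O)NC(C(=O)N[C@@H](CC(C)C)[C@@H](O)CC(C)C(=O)NC(C)C(=O)NC(=O)C(C)C)C(C)C`, 3 nM
compound 2, `CC(C)CCNC(=O)C(C)NC(=O)C(C)C[C@H](O)[C@H](CC(C)C)NC(=O)C(NC(=O)CC(C)C)C(C)C`, 3 nM
compound 3, `CC(C)CCNC(=O)C(C)NC(=O)C(C)CC(=O)[C@H](CC(C)C)NC(=O)C(NC(=O)CC(C)C)C(C)C`, 27 nM

In an assay on isolated protein for inhibition of Pepsin A (Sus scrofa) (a lower number here means a stronger inhibitor, a higher number a weaker inhibitor), compound 1 gives 3 nM and compound 2 gives 3 nM. The pair is a single change, (isopropylcarbonyl in place of isopentyl on an amide-type nitrogen), and the step reads no change at the digits printed from compound 2 to compound 1 (within the scatter). Compound 3 gives 27 nM in this assay, the highest of the three numbers and beyond the scatter against both compound 1 and compound 2. The difference between the core of compound 3 and the core of compound 2 is not broken down here.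

Compound 4, `CC(C)CC(=O)NC(C(=O)N[C@@H](CC(C)C)C(=O)CC(C)C(=O)NC(C)C(=O)NC(=O)C(C)C)C(C)C`, is not yet measured. It differs from compound 3 by isopropylcarbonyl in place of isopentyl on an amide-type nitrogen, and the place of the change is the same word for word as in the measured pair, so this is the same change made on the core of compound 3. For compound 4 the expected step is no change at the digits printed from compound 3 to compound 4 (within the scatter). This expectation rests on no change at the digits printed from compound 2 to compound 1 (within the scatter), where the identical change left the number where it stood. Compound 4 is therefore estimated at 27 nM, with a range from 12 nM to 60 nM.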

Compound 4, inhibition constant: 110 nM
Compound 4: middle estimate off by 4.1-fold (0.61 log units), on the low side; measured number above the stated range.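

In this assay, isopropylcarbonyl in place of isopentyl on an amide-type nitrogen gives a 4.1-fold higher number from compound 3 to compound 4 (0.61 log units; beyond the scatter), so the result on the core of compound 2 does not carry over to the core of compound 3, as the two steps set side by side show: the same change on two cores in this assay, no change at the digits printed (within the scatter) from compound 2 to compound 1 and a 4.1-fold higher number (0.61 log units; beyond the scatter) from compound 3 to compound 4, 4.1-fold (0.61 log units) apart, beyond the scatter of two such steps.
Within this pair of cores, the change therefore depends on the core that carries it, and a neutral result on one core gives no safe reading for the other. This rests on two pairs alone: it gives no general rule for other cores in the series and does not show what in the two cores separates the steps.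

Still open, from the compounds shown here alone, is whether the same dependence on the core appears with other groups on that nitrogen, such as a longer chain, an amine or a carboxylic acid. Also open, going by these compounds, is whether a third core would follow the core of compound 2 or the core of compound 3.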